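The compounds below may be only part of what the source reports. "The series", "measured", "known", "first", "only" and "open" are said of these compounds alone.

Compound 1, with structure `CC(C)Cc1ccc2c(NCCCNCc3ccco3)ccnc2c1`, gives the highest number of the three compounds measured in an ADME assay on HepG2 cells (Homo sapiens) for cytotoxicity, read by luminescence, CellTiter-Glo and ATP content, with a stated time of 72 h (a higher number here means that more compound is needed for the effect, a lower number that less compound is needed), a value of 16000 nM. Compound 2, `c1ccc(Oc2ccc3c(NCCCNCc4ccco4)ccnc3c2)cc1`, gives 15200 nM in this assay, and compound 3, `Clc1ccc(Oc2ccc3c(NCCCNCc4ccco4)ccnc3c2)cc1`, gives 7800 nM. The step of a 1.1-fold lower number from compound 1 to compound 2 (0.02 log units; within the scatter) lies within the scatter, whereas a 2.1-fold lower number from compound 1 to compound 3 (0.31 log units; beyond the scatter) is a modest change beyond it; a 1.9-fold lower number from compound 2 to compound 3 (0.29 log units; within the scatter) again stays within the scatter.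

Compound 4, `FC(F)(F)c1cccc(Cc2ccc3c(NCCCNCc4ccco4)ccnc3c2)c1`, differs from compound 1 by 3-(trifluoromethyl)phenyl in place of isopropyl on a saturated chain carbon bound to an aromatic carbon. The shared core and the chain that carries the furan are untouched; only the group on the saturated chain carbon bound to an aromatic carbon changes, so that an isopropyl gives way to a 3-(trifluoromethyl)phenyl. The steps from compound 1 to compound 2 and to compound 3 bear on this, as each also exchanges the isobutyl for a larger aromatic substituent, and they ranged from no change to a modest lowering. Compound 4 is therefore expected to show a small step of a 1.7-fold lower number from compound 1 to compound 4 (0.23 log units; within the scatter) toward a lower number in this assay. The estimate for compound 4 is 9500 nM, within a range of 4000 nM to 22000 nM.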

Compound 4, half-maximal effective concentration: 3190 nM
Estimate against measurement, compound 4: 3.0-fold (0.47 log units) above; measured number outside the range, below it.
By their numbers in this assay, from the lowest: compound 4; then compounds 3, 2 and 1 (each within the scatter of the next, the first and the last beyond it).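

In this assay, the step of a 5.0-fold lower number from compound 1 to compound 4 (0.70 log units; beyond the scatter) lies beyond the scatter and shows that this place, a saturated chain carbon bound to an aromatic carbon, tolerates a 3-(trifluoromethyl)phenyl with less compound needed for the effect. The earlier compounds shown here exchanged the whole isobutyl for phenoxy or 4-chlorophenoxy, whereas here that saturated chain carbon stays and isopropyl, with 3 heavy atoms, gives way to a group of 10 heavy atoms carrying a six-membered aromatic ring. This is the first change shown at this place, so it gives one step and no trend.

The compounds shown leave open whether the step belongs to the ring or to the trifluoromethyl, and how a plain phenyl, a carboxylic acid or an amine there would read in this assay. Nothing among the data shown gives a cause for this step.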